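The source may report more compounds than this note shows. Statements on the series, on what has been measured and on what is new or still open speak of the compounds shown alone.

Within the data shown here, in an ADME assay on L02 cells (Homo sapiens) for cytotoxicity, read by MTT assay, with a stated time of 48 h (on this read-out lower numbers stand for stronger inhibition and higher numbers for weaker inhibition), three compounds built on a shared core have numbers so far. Compound 1 (`CCn1c(C(=O)NCCCN(C)C)ccc1C(CC)(CC)c1ccc(OCC(O)C(C)(C)C)c(C)c1`) gives 470 nM, compound 2 (`CCn1c(C(=O)NCCN)ccc1C(CC)(CC)c1ccc(OCC(O)C(C)(C)C)c(C)c1`) gives 2400 nM, and compound 3 (`C#CC(C)OC(=O)c1ccc(C(CC)(CC)c2ccc(OCC(O)C(C)(C)C)c(C)c2)n1CC`) gives 23700 nM, the highest number of the three. Compound 4 (`CCn1c(C(=O)OCc2ccc(F)cc2)ccc1C(CC)(CC)c1ccc(OCC(O)C(C)(C)C)c(C)c1`) has not yet been measured. It departs from compound 3 by one change: 4-fluorobenzyl in place of 1-methylprop-2-yn-1-yl on an oxygen next to a carbonyl group. Put another way, (1-methylprop-2-yn-1-yl)oxy gives way to (4-fluorobenzyl)oxy on the same carbonyl carbon.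

The nearest evidence comes from changes at that carbonyl carbon. The data show a 50-fold higher number from compound 1 to compound 3 (1.70 log units; beyond the scatter) and a 9.9-fold higher number from compound 2 to compound 3 (0.99 log units; beyond the scatter), both with (1-methylprop-2-yn-1-yl)oxy entering in place of an amino-bearing chain. Further out on such a chain, the data show a 5.1-fold higher number from compound 1 to compound 2 (0.71 log units; beyond the scatter). These steps show that the number can move with changes at this end of the molecule. None of them, however, keeps the oxygen and alters only the group on it, as the change to compound 4 does. They therefore give no direction for this change, and their sizes cannot simply be carried over. The expected change is small, a 1.3-fold lower number from compound 3 to compound 4 (0.12 log units; within the scatter), with no step beyond the scatter anticipated. Compound 4 is estimated at 18000 nM, with an expected range from 6000 nM to 45000 nM.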

Compound 4, half-maximal inhibitory concentration: 14900 nM
The estimate for compound 4 lay 1.2-fold (0.08 log units) above the measured number; low and high end bracket the measured number.
By their numbers in this assay, from the lowest: compound 1; then compound 2; then compounds 4 and 3 (each within the scatter of the next).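

In this assay, the change from 1-methylprop-2-yn-1-yl to 4-fluorobenzyl on an oxygen next to a carbonyl group is the first step to keep that oxygen and alter only the group on it, and it gives a 1.6-fold lower number from compound 3 to compound 4 (0.20 log units; within the scatter); among these two compounds, a group of 8 heavy atoms with a six-membered aromatic ring thus stands in place of one of 4 heavy atoms with no shift beyond the scatter. A second group on the oxygen also shows that the gap to the amino-bearing chains does not rest on compound 3 alone, since (4-fluorobenzyl)oxy in place of those chains gives a 6.2-fold higher number from compound 2 to compound 4 (0.79 log units; beyond the scatter) and a 32-fold higher number from compound 1 to compound 4 (1.50 log units; beyond the scatter), so both oxygen-linked compounds sit apart from both amides, with none of the four going against this. Nothing available explains these numbers.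

The compounds shown leave open whether the lower numbers follow the amide nitrogen or the amine at the end of its chain, which an amide with a plain alkyl chain, or a benzyl ester carrying a dimethylamino group, would separate. They also leave open what the fluorine contributes to compound 4, and how a plain benzyl group or a free carboxylic acid at the same carbonyl carbon would read.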